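This account rests on a few compounds, and the source may have more. Where it says the series, first, only, none or still open, it means among the compounds named here.

Measured so far:
compound 1 `CC(C)=CCOc1ccc2c(c1)OC(c1cccc(Cl)c1)CC2=O`, in a functional assay; on this read-out lower numbers stand for stronger inhibition and higher numbers for weaker inhibition: 6300 nM
compound 2 `CC(C)=CCOc1ccc2c(c1)OC(c1ccc(Cl)cc1)CC2=O`, in this assay: 6970 nM
compound 3 `CC(C)=CCOc1cc(O)c2c(c1)OC(c1cccc(Cl)c1)CC2=O`, in this assay: 6060 nM

The three numbers sit close together. The change from compound 1 to compound 2 is 4-chlorophenyl in place of 3-chlorophenyl on a saturated ring carbon; it gave a 1.1-fold higher number from compound 1 to compound 2 (0.04 log units; within the scatter). The core of compound 3 differs from the core of compound 1 by hydroxy in place of hydrogen on an aromatic carbon, and that change gave a 1.0-fold lower number from compound 1 to compound 3 (0.02 log units; within the scatter). Compound 2 and compound 3 are also within the scatter of each other, so no order among the three can be read from these numbers.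

Compound 4 `CC(C)=CCOc1cc(O)c2c(c1)OC(c1ccc(Cl)cc1)CC2=O` has not yet been measured. For the measured compounds named here, it differs from compound 3 by 4-chlorophenyl in place of 3-chlorophenyl on a saturated ring carbon, which is the same change as the one from compound 1 to compound 2, at the same place. For compound 4 the expected step is a 1.1-fold higher number from compound 3 to compound 4 (0.04 log units; within the scatter), set beside a 1.1-fold higher number from compound 1 to compound 2 (0.04 log units; within the scatter). This rests on that one earlier step only, because a 1.1-fold higher number from compound 1 to compound 2 (0.04 log units; within the scatter) stayed within the scatter. For compound 4 the estimate is 6700 nM, expected between 3500 nM and 13000 nM.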

Compound 4, half-maximal inhibitory concentration: 7020 nM
For compound 4 the middle estimate is 1.0-fold (0.02 log units) below the measured one; low and high end bracket the measured number.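

Putting 4-chlorophenyl in place of 3-chlorophenyl on the saturated ring carbon gave a 1.2-fold higher number from compound 3 to compound 4 (0.06 log units; within the scatter) in this assay, and this agrees with the earlier step: the same change on two cores in this assay, a 1.1-fold higher number (0.04 log units; within the scatter) from compound 1 to compound 2 and a 1.2-fold higher number (0.06 log units; within the scatter) from compound 3 to compound 4, 1.0-fold (0.02 log units) apart, within the scatter of two such steps

Hydroxy in place of hydrogen on an aromatic carbon gave a 1.0-fold higher number from compound 2 to compound 4 (0.00 log units; within the scatter), which also agrees with its earlier counterpart: the same change on two cores in this assay, a 1.0-fold lower number (0.02 log units; within the scatter) from compound 1 to compound 3 and a 1.0-fold higher number (0.00 log units; within the scatter) from compound 2 to compound 4, 1.0-fold (0.02 log units) apart, within the scatter of two such steps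

Both changes therefore carry from one core to the other in the limited sense that each stays within the scatter on both cores, but this does not show that either change has a real effect or that a larger step would transfer in the same way.

The compounds shown leave open whether an amine or a carboxylic acid in place of the chlorine would give a step beyond the scatter in this assay. If such a step appeared, whether it would hold on both the hydroxy-bearing core and the core without the hydroxy would remain a separate question.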